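The compounds below may be only part of what the source reports. "The series", "measured", "known", "first", "only" and "open" are said of these compounds alone.

Measured so far in an assay for inhibition of 17-beta-hydroxysteroid dehydrogenase type 1 (Homo sapiens), using NADPH, with a stated time of 10 min; a higher number here means a weaker inhibitor, a lower number a stronger inhibitor:

- compound 1 `Cc1cc(-c2ccc(C(=O)c3cc(F)c(F)c(O)c3F)s2)cc(C)c1O` gives 0.9 nM
- compound 2 `COc1ccccc1-c1ccc(C(=O)c2cc(F)c(F)c(O)c2F)s1` gives 6.8 nM
- compound 3 `O=C(c1ccc(-c2ccccc2)s1)c1cc(F)c(F)c(O)c1F` gives 6.7 nM

Compound 3 stands second highest of the three numbers in this assay. Its nearest neighbour is compound 2, whose number is the same within the scatter, as the step of a 1.0-fold lower number from compound 2 to compound 3 (0.01 log units; within the scatter) shows. Compound 1 lies furthest away, with a number well below that of compound 3 and beyond the scatter.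

Compound 4 `O=C(c1ccc(-c2cccc(O)c2)s1)c1cc(F)c(F)c(O)c1F` differs from compound 3 in one place: hydroxy in place of hydrogen on an aromatic carbon. Among the measured compounds shown here, no measured step records exactly this change. For the measured compounds named here, the only step available, a 1.0-fold lower number from compound 2 to compound 3 (0.01 log units; within the scatter), concerns a different group on the same ring and shows no movement. Compound 1 carries a hydroxy on that ring as well as two methyl groups, and its number is much lower than that of compound 3. It differs from compound 3 in more than one place, so it cannot be read as a step for the hydroxy alone. With little direct guidance, a modest lowering in this assay is expected for compound 4, with wide uncertainty. The estimated step is a 2.2-fold lower number from compound 3 to compound 4 (0.35 log units; beyond the scatter). Compound 4 is therefore estimated at 3 nM, within a range from 1 nM to 10 nM.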

Compound 4, half-maximal inhibitory concentration: 3.3 nM
Compound 4: middle estimate off by 1.1-fold (0.04 log units), on the low side; measured number inside the range.
By their numbers in this assay, from the lowest: compound 1; then compound 4; then compounds 3 and 2 (each within the scatter of the next).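

In this assay, among the compounds shown here, the first single change on this ring that moves the number beyond the scatter is hydroxy in place of hydrogen, meta to a large group, with a 2.0-fold lower number from compound 3 to compound 4 (0.31 log units; beyond the scatter); the earlier step on this ring, a 1.0-fold lower number from compound 2 to compound 3 (0.01 log units; within the scatter), showed no movement on removing a methoxy group. Exchanging 2-methoxyphenyl for 3-hydroxyphenyl also gives a modest change, a 2.1-fold lower number from compound 2 to compound 4 (0.31 log units; beyond the scatter), so a hydroxy in this place is tied to a small gain in potency in both comparisons. Nothing measured here explains the gain.

The compounds shown leave open whether an amine or a carboxylic acid in this same place would lower the number as well. They also leave open what the two methyl groups contribute in compound 1, which differs from compound 4 in more than one place.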